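Two Hydroxyalkyl Amides Tested for Receptor Binding

The source may hold more compounds than are shown below. What is called first, only, known or untested is meant among the compounds shown, and "the series" means these compounds.

Going by the values given here, compound 2 `CCC(CO)NC(=O)c1cc2cc(Br)ccc2oc1=N` and compound 1 `COc1cc(Br)cc2cc(C(=O)NCCCO)c(=N)oc12` are the two compounds measured so far. In an assay on HeLa cells for displacement of a labelled ligand from adenosine receptor A3 (Homo sapiens), read by scintillation counting, with a stated time of 180 min, tested at 10 uM (a lower number here means less inhibition, a higher number more inhibition at the concentration tested (going by the name of the read-out)), compound 2 gives 24%, and compound 1 gives 23%; the two numbers lie within the usual scatter of each other, so neither stands apart. Compound 3 `N=c1oc2ccc(Br)cc2cc1C(=O)NCCCO` has not yet been measured. It differs from compound 2 by 3-hydroxypropyl in place of 1-(hydroxymethyl)propyl on an amide-type nitrogen. Among the compounds with values here, no measured pair shows this change on its own, so the step of a number 1 percentage points lower from compound 2 to compound 3 (within the scatter) is expected to stay within the scatter. Compound 3 is therefore expected to give about 23%, with a range from 8% to 38%.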

Compound 3, a percentage reported as inhibition, at one concentration (the size of the read-out at that concentration, not a potency): 17%
The estimate for compound 3 lay 6 percentage points above the measured number; the range from low to high includes it.
By their numbers in this assay, from the lowest: compounds 3, 1 and 2 (each within the scatter of the next).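

In this assay, going by these compounds alone, 3-hydroxypropyl in place of 1-(hydroxymethyl)propyl on the amide-type nitrogen gives a number 7 percentage points lower from compound 2 to compound 3 (within the scatter), so this chain swap, seen here on its own for the first time, does not separate the two compounds. Hydrogen in place of methoxy on an aromatic carbon gives a number 6 percentage points lower from compound 1 to compound 3 (within the scatter), so that swap does not separate its pair either. Nothing available here offers an explanation for these numbers. The compounds shown leave open whether a longer chain or an amine on the amide-type nitrogen would move the number beyond the scatter.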